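The compounds below may be only part of what the source reports. "The series", "measured", "known", "first", "only" and "open" are said of these compounds alone.

Going by the values given here, compound 1 `O=C(NCC1CCN(CCCS(=O)(=O)N2CCN(c3ccccn3)CC2)CC1)c1cccc2c1OCCO2` gives 0.251 nM in an assay on isolated protein for inhibition of 5-hydroxytryptamine receptor 4 (Homo sapiens) (on this read-out lower numbers stand for stronger inhibition and higher numbers for weaker inhibition), the highest of the three numbers measured so far. Compound 2 `CC(=O)N1CCN(S(=O)(=O)CCCN2CCC(CNC(=O)c3cccc4c3OCCO4)CC2)CC1` gives 0.126 nM in this assay, and compound 3 `O=C(NCC1CCN(CCCS(=O)(=O)N2CCN(C3CCCC3)CC2)CC1)c1cccc2c1OCCO2` gives 0.0159 nM. Compound 4 `CCCS(=O)(=O)N1CCN(S(=O)(=O)CCCN2CCC(CNC(=O)c3cccc4c3OCCO4)CC2)CC1` differs from compound 1 by propylsulfonyl in place of pyridin-2-yl on an amine nitrogen in a ring. Two measured steps replace the same group on the same ring nitrogen: a 2.0-fold lower number from compound 1 to compound 2 (0.30 log units; within the scatter) and a 16-fold lower number from compound 1 to compound 3 (1.20 log units; beyond the scatter). Propylsulfonyl, like acetyl, has no ring, so the step to compound 4 is expected to be a small move downward in the manner of compound 2, with some chance of a larger one as seen for compound 3. Compound 4 is therefore expected at 0.13 nM in this assay, within 0.04 nM to 0.4 nM. That estimate means a step of a 1.9-fold lower number from compound 1 to compound 4 (0.29 log units; within the scatter).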

Compound 4, inhibition constant: 0.1 nM
Beside the measured number, compound 4's estimate is 1.3-fold (0.11 log units) above it; the measured number falls inside the stated range.
By their numbers in this assay, from the lowest: compound 3; then compounds 4, 2 and 1 (each within the scatter of the next, the first and the last beyond it).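

Propylsulfonyl on the ring nitrogen carries the number beyond the scatter from pyridin-2-yl (a 2.5-fold lower number from compound 1 to compound 4 (0.40 log units; beyond the scatter)). It cannot be told apart from acetyl (a 1.3-fold lower number from compound 2 to compound 4 (0.10 log units; within the scatter)), so a sulfonyl group and a carbonyl group at this position give values within the scatter of each other in this pair. Cyclopentyl stays clearly apart from propylsulfonyl (a 6.3-fold higher number from compound 3 to compound 4 (0.80 log units; beyond the scatter)), as it did from acetyl. Whether cyclohexyl or a plain butyl chain on this nitrogen would group with cyclopentyl or with propylsulfonyl remains open, and nothing measured here gives a reason for these differences.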